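Benzyl in Place of Propyl on the Ester Side Chain

The source may hold more compounds than are shown below. What is called first, only, known or untested is meant among the compounds shown, and "the series" means these compounds.

The three measured compounds share one core and differ only in the groups on their two ester oxygens. Compound 1 `CCCOC(=O)C1=C(C)NC(C)=C(C(=O)OC)C1c1[nH]c(CC)nc1Cl` carries a methyl ester and a propyl ester; in an assay on ileum for inhibition of Voltage-dependent L-type calcium channel subunit alpha-1C (Cavia porcellus) (on this read-out higher numbers stand for weaker inhibition and lower numbers for stronger inhibition), compound 1 gives 0.146 nM. Compound 2 `CCCOC(=O)C1=C(C)NC(C)=C(C(=O)OCCC)C1c1[nH]c(CC)nc1Cl`, with two propyl esters, gives 0.13 nM in this assay, and the step of a 1.1-fold lower number from compound 1 to compound 2 (0.05 log units; within the scatter) shows that this change leaves the number essentially where it was. Among the measured compounds shown here, compound 3 `CCc1nc(Cl)c(C2C(C(=O)OCC(C)C)=C(C)NC(C)=C2C(=O)OCC(C)C)[nH]1`, carrying two isobutyl esters, gives 2.64 nM in this assay; it differs from compound 1 in two places at once, so no single step links the pair, and only the two values can be compared. Compound 1 therefore stands second highest of the three numbers: its nearest neighbour is compound 2, within the scatter, and its furthest is compound 3, well beyond it.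

Compound 4 `CCc1nc(Cl)c(C2C(C(=O)OC)=C(C)NC(C)=C2C(=O)OCc2ccccc2)[nH]1` differs from compound 1 by phenyl in place of ethyl on a saturated chain carbon bound to an oxygen next to a carbonyl group, so the propoxycarbonyl of compound 1 becomes a benzyloxycarbonyl. For the measured compounds named here, the one step measured at this place, from compound 1 to compound 2, stayed within the scatter, while the bulkier pair of esters in compound 3 went with a clearly higher number. A change here is therefore expected to shift the number only modestly, if at all, and more likely upward than downward. Compound 4 is expected to give about 0.4 nM in this assay, with a likely range from 0.1 nM to 1.5 nM. That estimate corresponds to an expected step of a 2.7-fold higher number from compound 1 to compound 4 (0.44 log units; beyond the scatter).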

Compound 4, half-maximal inhibitory concentration: 1.75 nM
Beside the measured number, compound 4's estimate is 4.4-fold (0.64 log units) below it; the whole stated range lies below it.
By their numbers in this assay, from the lowest: compounds 2 and 1 (each within the scatter of the next); then compounds 4 and 3 (each within the scatter of the next).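

Among the compounds shown here, replacing propyl with benzyl in this assay gives a 12-fold higher number from compound 1 to compound 4 (1.08 log units; beyond the scatter), a large step and the first single change to reach beyond the scatter. For the compounds shown here, the only earlier single step on a saturated chain carbon bound to an oxygen next to a carbonyl group, a 1.1-fold lower number from compound 1 to compound 2 (0.05 log units; within the scatter), had left the number essentially unmoved, so the earlier pair gave no sign that a change of this kind could matter so much. The result shows that the number in this assay does not stay the same whatever group the ester carries, and that a phenyl in place of ethyl is enough to weaken inhibition clearly. Nothing given here accounts for the size of this step.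

The compounds shown leave open whether the aromatic ring itself goes with the higher number, since a single benzyl ester cannot separate it from other differences between the two groups. A cyclohexylmethyl ester, a phenethyl ester or a longer chain such as hexyl on this oxygen would each bear on that question, as would a benzyl ester in place of the methyl ester of compound 1.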